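What a (2-nitrophenyl)sulfonyl group may do to compound 3

The compounds below may be only part of what the source reports. "The series", "measured", "known", "first", "only" and "open" are said of these compounds alone.

Compound 1 `N#Cc1c(NN)nc(SCc2nc3ccccc3[nH]2)nc1-c1ccccc1` gives 2.55 nM
Compound 2 `N#Cc1c(Nc2nccs2)nc(SCc2nc3ccccc3[nH]2)nc1-c1ccccc1` gives 14.7 nM
Compound 3 `N#Cc1c(-c2ccccc2)nc(SCc2nc3ccccc3[nH]2)nc1N1CCNCC1` gives 2.87 nM

All three values come from a functional assay on KB cells (Homo sapiens) for cytotoxicity, read by MTT assay, with a stated time of 3 days; a lower number here means a stronger inhibitor, a higher number a weaker inhibitor. Compound 3 is second highest of the three numbers, level with compound 1 and apart from compound 2, as a 5.1-fold lower number from compound 2 to compound 3 (0.71 log units; beyond the scatter) shows. Compound 4 `N#Cc1c(-c2ccccc2)nc(SCc2nc3ccccc3[nH]2)nc1N1CCN(S(=O)(=O)c2ccccc2[N+](=O)[O-])CC1` has (2-nitrophenyl)sulfonyl in place of hydrogen on an amine nitrogen in a ring. Among the compounds with values here, no measured compound carries a group on that nitrogen, so the evidence is indirect. Two measured steps are a 5.8-fold higher number from compound 1 to compound 2 (0.76 log units; beyond the scatter) and a 1.1-fold higher number from compound 1 to compound 3 (0.05 log units; within the scatter), and neither lowered the number, so a modest rise is expected. In this assay the expected change is a 2.4-fold higher number from compound 3 to compound 4 (0.39 log units; beyond the scatter), a rough estimate. The estimate for compound 4 is 7 nM, with an expected range from 1.5 nM to 35 nM.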

Compound 4, half-maximal inhibitory concentration: 4.44 nM
Estimate against measurement, compound 4: 1.6-fold (0.20 log units) above; the range from low to high includes it.
By their numbers in this assay, from the lowest: compounds 1, 3 and 4 (each within the scatter of the next); then compound 2.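

The amine nitrogen in the ring now carries a group, and in this assay (2-nitrophenyl)sulfonyl in place of hydrogen gives a 1.5-fold higher number from compound 3 to compound 4 (0.19 log units; within the scatter). So a group of 12 heavy atoms, with its own aromatic ring, can sit on this nitrogen while the number stays within the usual scatter of compound 3. Within the data shown here, this is the first reading at this position, which the earlier compounds left bare.

From the compounds shown here alone, whether a methyl, an acetyl or a plain phenylsulfonyl on that nitrogen would behave alike stays open. No measured evidence speaks to why the number holds here.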